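Halogenated aryl ureas on a shared quinazoline-free core

The source may hold more compounds than are shown below. What is called first, only, known or untested is meant among the compounds shown, and "the series" means these compounds.

Three ureas built on one shared core have been measured. Compound 1 `COc1cc(Nc2ncnc3c(NC(=O)Nc4cc(Cl)c(Cl)cc4Cl)cccc23)cc(OC)c1` carries 2,4,5-trichlorophenyl on the urea nitrogen, and in a functional assay on RT-112 cells (Homo sapiens) for antiproliferative activity, read by MTT assay, with a stated time of 72 h (on this read-out lower numbers stand for stronger inhibition of growth and higher numbers for weaker inhibition of growth), compound 1 gives 4890 nM. Compound 2 `COc1cc(Nc2ncnc3c(NC(=O)Nc4ccc(F)cc4C(F)(F)F)cccc23)cc(OC)c1` carries 4-fluoro-2-(trifluoromethyl)phenyl, and in this assay compound 2 gives 2970 nM; the difference a 1.6-fold lower number from compound 1 to compound 2 (0.22 log units; within the scatter) keeps the two side by side. Compound 3 `COc1cc(Nc2ncnc3c(NC(=O)Nc4ccc([N+](=O)[O-])cc4)cccc23)cc(OC)c1` carries 4-nitrophenyl, and in this assay compound 3 gives > 20000 nM, which is a limit of the assay and not a number. Compound 3 thus stands at the limit of > 20000 nM in this assay, at which 1 of the 3 values shown sits, the weakest position among the values shown, with the steps of an at least 4.0-fold higher number from compound 1 to compound 3 (0.61 log units; beyond the scatter) and an at least 6.7-fold higher number from compound 2 to compound 3 (0.82 log units; beyond the scatter) both beyond the scatter.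

Compound 4 `COc1cc(Nc2ncnc3c(NC(=O)Nc4ccc(C(F)(F)F)cc4Cl)cccc23)cc(OC)c1` has not yet been measured. It differs from compound 3 by 2-chloro-4-(trifluoromethyl)phenyl in place of 4-nitrophenyl on an amide-type nitrogen. The incoming group resembles the halogenated phenyls of compound 1 and compound 2, both of which sit well below the limit, and both measured steps toward 4-nitrophenyl raised the number. The expected step therefore runs the other way and is estimated as an at least 5.0-fold lower number from compound 3 to compound 4 (0.69 log units; beyond the scatter). In this assay compound 4 is expected to give 4000 nM, with a likely range from 1500 nM to 12000 nM.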

Compound 4, concentration for 50% growth inhibition: 1080 nM
The estimate for compound 4 lay 3.7-fold (0.57 log units) above the measured number, and the stated range ends above it.
By their numbers in this assay, from the lowest: compound 4; then compounds 2 and 1 (each within the scatter of the next). At a limit, above all of these: compound 3.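

Among the compounds shown here, at the aryl group on the amide-type nitrogen, the earlier compounds set 4-nitrophenyl apart from two halogenated phenyls that could not be told from each other, but compound 4 now shows that the choice among halogenated phenyls also matters in this assay, with a 2.8-fold lower number from compound 2 to compound 4 (0.44 log units; beyond the scatter) and a 4.5-fold lower number from compound 1 to compound 4 (0.66 log units; beyond the scatter). For the compounds shown here, exchanging the nitro-bearing ring for 2-chloro-4-(trifluoromethyl)phenyl gives the widest step at this place so far, an at least 18-fold lower number from compound 3 to compound 4 (1.26 log units; beyond the scatter), and the true size of that step remains open on one side. Compound 3 stands at a limit of the assay and not at a number: the limit of > 20000 nM in this assay, at which 1 of the 4 values shown sits.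

On these data alone, how a phenyl carrying only the chlorine or only the trifluoromethyl group would compare remains open, so the step to compound 4 cannot be assigned to either substituent. Also open, as far as these compounds go, is what a nitrile or an amine on this phenyl ring would do, and whether the order seen here holds outside this one cell line or with any change to the shared core.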